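Extending the chain: from compound 2 toward compound 4

The source may report more compounds than this note shows. Statements on the series, on what has been measured and on what is new or still open speak of the compounds shown alone.

Measured so far:
- compound 1 `Cc1cccc(NS(=O)(=O)c2ccc(N3CCNC3=O)cc2)c1` gives 69 nM in a functional assay on M21 cells (Homo sapiens) for antiproliferative activity, read by sulforhodamine B assay, with a stated time of 48 h; on this read-out lower numbers stand for stronger inhibition and higher numbers for weaker inhibition
- compound 2 `CCCCc1ccc(NS(=O)(=O)c2ccc(N3CCNC3=O)cc2)cc1` gives 450 nM in this assay
- compound 3 `Cc1ccc(NS(=O)(=O)c2ccc(N3CCNC3=O)cc2)c(C)c1` gives 150 nM in this assay

Compound 2 stands at the highest number of the three, which on this read-out means the weakest inhibition: compound 3 is nearer to it and compound 1 furthest away, both with gaps beyond the usual scatter. For the measured compounds named here, the only measured step that changes one place is a 2.2-fold higher number from compound 1 to compound 3 (0.34 log units; beyond the scatter), and that concerns the pattern of methyl groups on the ring, not the length of a chain.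

Compound 4 `CCCCCc1ccc(NS(=O)(=O)c2ccc(N3CCNC3=O)cc2)cc1` differs from compound 2 by methyl in place of hydrogen on a saturated chain carbon, four bonds along the chain from an aromatic carbon. Going by the values given here, no measured pair shows what lengthening this chain does, so the expectation rests on the general observation that such small additions far from the core usually move the number little. The step is therefore expected to lie within or only just beyond the scatter, with a slight lean toward a higher number given that compound 2 already sits at 450 nM. Compound 4 is thus estimated at 600 nM, within 200 nM to 2000 nM, an expected step of a 1.3-fold higher number from compound 2 to compound 4 (0.12 log units; within the scatter).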

Compound 4, half-maximal inhibitory concentration: 870 nM
Compound 4: the middle estimate sits 1.5-fold (0.16 log units) below what was measured; low and high end bracket the measured number.
By their numbers in this assay, from the lowest: compound 1; then compound 3; then compounds 2 and 4 (each within the scatter of the next).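

In this assay, for the compounds shown here, the new step, a 1.9-fold higher number from compound 2 to compound 4 (0.29 log units; within the scatter), is the first measured change to the length of a saturated chain, and it stays inside the usual scatter of repeated measurements. One more methyl at this place, four bonds along the chain from an aromatic carbon, therefore leaves compound 2 and compound 4 indistinguishable on this read-out, so this single pair gives no sign that the added carbon matters, although it cannot establish a trend on its own. No independent measurement is available to explain the size of this step.

A single step cannot show what happens as the chain changes further: a longer chain such as hexyl, or a chain ending in an amine or a carboxylic acid, might stay level with compound 2 and compound 4 or move clearly away from them. Going by these compounds, it also remains open how a shorter chain, such as ethyl or propyl in the same place, would read in this assay, and whether chain length has any effect across a wider range.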